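One more methyl on the nitrogen of compound 3

This account rests on a few compounds, and the source may have more. Where it says the series, first, only, none or still open, it means among the compounds named here.

Compound 1 `COc1ccc(N(C)c2ncnc3occ(C)c23)cc1` gives 80 nM
Compound 2 `CCc1ccc(N(C)c2ncnc3occ(C)c23)cc1` gives 287 nM
Compound 3 `CNc1ccc(N(C)c2ncnc3occ(C)c23)cc1` gives 707 nM

In a functional assay on Chorioallantoic membrane (Gallus gallus, strain Leghorn), read by microscopy, with a stated time of 40 h (a lower number here means a stronger inhibitor, a higher number a weaker inhibitor), compound 3 stands at 707 nM as the highest of the three numbers, which makes it the weakest inhibitor measured so far. The change leading to compound 4 `Cc1coc2ncnc(N(C)c3ccc(N(C)C)cc3)c12` is methyl in place of hydrogen on a nitrogen on an aromatic ring and it turns methylamino into dimethylamino.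

Going by the values given here, no measured step covers this exact change, so the evidence is indirect. Three swaps of the same group have been measured: a 3.6-fold higher number from compound 1 to compound 2 (0.55 log units; beyond the scatter) and a 2.5-fold higher number from compound 2 to compound 3 (0.39 log units; beyond the scatter) and an 8.8-fold higher number from compound 1 to compound 3 (0.95 log units; beyond the scatter) in that order. All three are modest, and methylamino sits at the high end in both steps that involve it. Three compounds give no rule for a methyl on that nitrogen, but a modest step towards a lower number is expected, and a step within the scatter remains possible. The estimated step is a 2.8-fold lower number from compound 3 to compound 4 (0.45 log units; beyond the scatter) on this reading. Compound 4 is expected at 250 nM within an estimated range from 80 nM to 700 nM on the same reading.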

Compound 4, half-maximal inhibitory concentration: 653 nM
Compound 4: middle estimate off by 2.6-fold (0.42 log units), on the low side, and the stated range covers the measured number.
By their numbers in this assay, from the lowest: compound 1; then compound 2; then compounds 4 and 3 (each within the scatter of the next).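

In this assay, going by these compounds alone, methyl in place of hydrogen on the nitrogen gives a 1.1-fold lower number from compound 3 to compound 4 (0.03 log units; within the scatter) and so has no effect that can be told from the scatter, which is the first measurement of a change at this nitrogen itself. Dimethylamino therefore behaves as methylamino did against the other two groups, with ethyl to dimethylamino giving a 2.3-fold higher number from compound 2 to compound 4 (0.36 log units; beyond the scatter) and methoxy to dimethylamino giving an 8.2-fold higher number from compound 1 to compound 4 (0.91 log units; beyond the scatter) on the same aromatic carbon. Nothing measured here explains why the two amino groups give such similar numbers.

The compounds shown leave open whether a longer chain on that nitrogen, as in diethylamino, or a ring amine such as morpholine would also match compounds 3 and 4. They also leave open how ethoxy or a plain amine on that aromatic carbon would compare with the methoxy of compound 1.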